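The source may report more compounds than this note shows. Statements on the series, on what has been measured and on what is new or still open speak of the compounds shown alone.

Compound 2 `CCCCCCCCCCCCCCC(N)CNCC(=O)O` is the weaker of the two compounds that have been measured in a functional assay on Jurkat cells (Homo sapiens) for inhibition; on this read-out lower numbers stand for stronger inhibition and higher numbers for weaker inhibition. Compound 2 gives 31000 nM, while compound 1 `CCCCCCCCCCCCCCC(N)CO` gives 7000 nM. Among the compounds with values here, the single step that links them, a 4.4-fold higher number from compound 1 to compound 2 (0.65 log units; beyond the scatter), replaces a hydroxy with a (carboxymethyl)amino group and so sets compound 2 at the upper end of the numbers so far.

Compound 3 `CCCCCCCCCCCCCCC(N)CNCCCCC(=O)O` is the next compound to be measured in this assay. Relative to compound 2 it carries 3-carboxypropyl in place of carboxy on a saturated chain carbon bound to an amine nitrogen. Within the data shown here, no measured step reports the effect of lengthening the carboxylic arm itself; the only step on record concerns the introduction of that arm, and it moved the number modestly upward from compound 1 to compound 2. Among the measured compounds shown here, a longer arm has no precedent among the measured pairs. A step of modest size in either direction, or none beyond the scatter, is therefore the expectation for compound 3 in this assay, written as a 1.6-fold lower number from compound 2 to compound 3 (0.19 log units; within the scatter). Compound 3 is accordingly estimated at 20000 nM, with a plausible range from 5000 nM to 80000 nM.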

Compound 3, half-maximal inhibitory concentration: 55000 nM
The estimate for compound 3 lay 2.8-fold (0.44 log units) below the measured number; the measured number falls inside the stated range.
By their numbers in this assay, from the lowest: compound 1; then compounds 2 and 3 (each within the scatter of the next).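

In this assay, putting 3-carboxypropyl in place of carboxy on a saturated chain carbon bound to an amine nitrogen gives a result that stays within the scatter (a 1.8-fold higher number from compound 2 to compound 3 (0.25 log units; within the scatter)), so the two arms cannot be told apart at this position, a comparison of arm length that compound 1 and compound 2 alone could not offer. Set against the hydroxy of compound 1, the (4-carboxybutyl)amino group gives a step beyond the scatter (a 7.9-fold higher number from compound 1 to compound 3 (0.90 log units; beyond the scatter)), which means that both arms carrying a carboxylic acid now stand on the same side of compound 1 and the upward step seen with compound 2 is not confined to a single arm. No evidence is available to account for these numbers.

The compounds shown leave open whether a still longer chain on the arm would stay within the scatter of compound 2 and compound 3. They also do not tell whether an ester, an amide or a plain alkyl chain in place of the carboxylic acid would keep the number on that side of compound 1.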